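A Piperidin-1-yl Swap on One Side Chain

The source may report more compounds than this note shows. Statements on the series, on what has been measured and on what is new or still open speak of the compounds shown alone.

In an ADME assay on L6 cells (Rattus norvegicus) for cytotoxicity, read by resazurin assay, with a stated time of 72 h (a lower number here means a stronger inhibitor, a higher number a weaker inhibitor), compound 1 `CCN(CC)CC(=O)OC1CC2(N3CCCCC3)CC(c3ccccc3)C1C(c1ccccc1)C2` gives 23900 nM and compound 2 `CN1CCN(CC(=O)OC2CC3(N4CCCCC4)CC(c4ccccc4)C2C(c2ccccc2)C3)CC1` gives 29500 nM and these two numbers lie within the scatter of each other. Among the measured compounds shown here, compound 2 therefore stands level with its only measured neighbour, and no order can be drawn between them.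

Compound 3 `O=C(CN1CCCCC1)OC1CC2(N3CCCCC3)CC(c3ccccc3)C1C(c1ccccc1)C2` shares the core of compound 2 and differs from it at a single place, on a saturated chain carbon bound to a carbonyl carbon. There piperidin-1-yl takes the place of 4-methylpiperazin-1-yl, and the change reads piperidin-1-yl in place of 4-methylpiperazin-1-yl on a saturated chain carbon bound to a carbonyl carbon in full.

For the measured compounds named here, only one measured step bears on this change. At the same place, going from diethylamino to 4-methylpiperazin-1-yl gave a 1.2-fold higher number from compound 1 to compound 2 (0.09 log units; within the scatter) and on that single step no shift beyond the scatter is expected in this assay for the new change. One step is thin evidence, so the expected range is kept wide. The expectation amounts to a 1.2-fold lower number from compound 2 to compound 3 (0.07 log units; within the scatter) as the estimated step. Compound 3 is expected near 25000 nM in this assay with an estimated range of 12000 nM to 50000 nM for the coming measurement.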

Compound 3, half-maximal inhibitory concentration: 60400 nM
For compound 3 the middle estimate is 2.4-fold (0.38 log units) below the measured one, outside the stated range (above it).
By their numbers in this assay, from the lowest: compounds 1 and 2 (each within the scatter of the next); then compound 3.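

In this assay this place, on a saturated chain carbon bound to a carbonyl carbon, now shows a change that moves the number beyond the scatter: piperidin-1-yl in place of 4-methylpiperazin-1-yl gives a 2.0-fold higher number from compound 2 to compound 3 (0.31 log units; beyond the scatter) and is modest in size. Piperidin-1-yl in place of diethylamino gives a 2.5-fold higher number from compound 1 to compound 3 (0.40 log units; beyond the scatter) and is also modest, so compound 3 stands apart from both earlier compounds, while compound 1 and compound 2 remain within the scatter of each other. Nothing given here accounts for why piperidin-1-yl parts from the other two groups at this place.

What the compounds leave open is whether this step belongs to piperidin-1-yl in particular or extends to other rings at the same place, since a pyrrolidin-1-yl or a morpholin-4-yl group does not appear among them. They also leave open how the number would respond to a change elsewhere, as the piperidin-1-yl group on the shared core and both phenyl groups stay the same in all three compounds.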